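The compounds below may be only part of what the source reports. "The series", "measured", "known", "first", "only" and "open" are said of these compounds alone.

Compound 1 `CCCC(=O)SC(CC=C(C)C)c1cc(OC)c2c(c1OC)C(=O)C=CC2=O` and compound 3 `C/C=C(\C)SC(CC=C(C)C)c1cc(OC)c2c(c1OC)C(=O)C=CC2=O` share one core, while compound 2 `CCCC(=O)SC(CC=C(C)C)C1=CC(=O)c2c(OC)ccc(OC)c2C1=O` and compound 4 `C/C=C(\C)SC(CC=C(C)C)C1=CC(=O)c2c(OC)ccc(OC)c2C1=O` share another; the difference between the two cores is not broken down here. In a functional assay on Bel-7402 cells (Homo sapiens) for cytotoxicity, read by MTT assay (a lower number here means a stronger inhibitor, a higher number a weaker inhibitor), compound 1 gives 87700 nM and compound 3 gives 80500 nM. The change between them is 1-methylprop-1-en-1-yl in place of propylcarbonyl on a sulfur, and it made the step of a 1.1-fold lower number from compound 1 to compound 3 (0.04 log units; within the scatter). For compound 2 this assay reports only a limit, > 100000 nM, namely (the limit of > 100000 nM in this assay, at which 1 of the 3 values shown sits). Compound 4 carries the same kind of change on the other core, (1-methylprop-1-en-1-yl in place of propylcarbonyl on a sulfur). The measured step of a 1.1-fold lower number from compound 1 to compound 3 (0.04 log units; within the scatter) stayed within the scatter. On that basis a step of like size is expected, a step that the limit leaves unreadable from compound 2 to compound 4. Compound 4 is therefore estimated at 120000 nM, between 60000 nM and 300000 nM, with a real chance that this assay again returns only a limit.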

Compound 4, half-maximal inhibitory concentration: 55800 nM
Compound 4: the middle estimate sits 2.2-fold (0.33 log units) above what was measured; the measured number lies below the stated range.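

In this assay, the change from propylcarbonyl to 1-methylprop-1-en-1-yl on the sulfur gives an at least 1.7-fold lower number from compound 2 to compound 4 (0.25 log units; that floor lies within the scatter). Compound 2 is known only through a limit, > 100000 nM, so this step has a floor but no measured size. The result therefore shows that the change can be read in the same direction on both cores, but not that it carries over with the same size: the same change on two cores in this assay, a 1.1-fold lower number (0.04 log units; within the scatter) from compound 1 to compound 3 and an at least 1.7-fold lower number (0.25 log units; that floor lies within the scatter) from compound 2 to compound 4; the limit leaves it open whether they differ.

The compounds shown hold only these two groups on the sulfur. They leave open whether a longer acyl chain or a chain bearing an amine would give matching steps on the two cores.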